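This account rests on a few compounds, and the source may have more. Where it says the series, first, only, none or still open, it means among the compounds named here.

Working notes on the series. Two compounds have been run in a functional assay on MDA-MB-435 cells (Homo sapiens) for cytotoxicity, read by sulforhodamine B assay, with a stated time of 48 h, tested at 100 uM; on this read-out higher numbers stand for a weaker effect at the one concentration tested and lower numbers for a stronger effect. Compound 1, `COc1cc(-c2cc(/C=C/C(=O)c3ccc(N)cc3)[nH]n2)cc(OC)c1OC`, gives -85% in this assay. Compound 2, `COc1ccc(C(=O)/C=C/c2cc(-c3cc(OC)c(OC)c(OC)c3)n[nH]2)cc1OC`, gives -73% in this assay. Among the compounds with values here, on these two numbers compound 2 stands highest; the single step between them, a number 12 percentage points higher from compound 1 to compound 2 (beyond the scatter), puts compound 2 beyond the scatter of compound 1 and is the only step measured so far.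

Compound 3, `COc1ccc(C(=O)/C=C/c2cc(-c3cc(OC)c(OC)c(OC)c3)n[nH]2)cc1`, is not yet measured in this assay. It differs from compound 2 by hydrogen in place of methoxy on an aromatic carbon. Within the data shown here, the one measured step bears on the same aryl group on the carbonyl carbon: exchanging that whole group in the step from compound 1 to compound 2 moved the number by a modest amount. Removing one methoxy from that group is a smaller change than exchanging the group, so a step in this assay of at most modest size is expected, most likely a small rise, and possibly none beyond the scatter. Compound 3 is therefore expected to give about -65% in this assay, within -85% to -40%, a step of a number 8 percentage points higher from compound 2 to compound 3 (within the scatter) that is expected rather than known.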

Compound 3, a percentage reported as activity, at one concentration (the size of the read-out at that concentration, not a potency): -44%
Compound 3: the middle estimate sits 21 percentage points below what was measured; the range from low to high includes it.
By their numbers in this assay, from the lowest: compound 1; then compound 2; then compound 3.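

In this assay, hydrogen in place of methoxy gives a number 29 percentage points higher from compound 2 to compound 3 (beyond the scatter), so going from 3,4-dimethoxyphenyl to 4-methoxyphenyl weakens the effect at the one concentration tested, and a single methoxy on this aryl group is enough to move the read-out beyond the scatter. Methoxy in place of amino on an aromatic carbon gives a number 41 percentage points higher from compound 1 to compound 3 (beyond the scatter), which shows that the group held at that place on the ring also matters, with the 4-aminophenyl compound giving the stronger effect of the pair. No measurement at hand gives a reason for either step.

The compounds shown leave open whether a hydroxy group, a fluorine or a dimethylamino group at either place on this aryl group would keep the stronger effect or lose it, and what an unsubstituted phenyl group would give. They also leave open whether these steps would hold with a different aryl group on the other side of the shared core, and how they would read at concentrations other than the single one tested here.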